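Swapping a dimethoxyphenyl for a fluorophenyl on the saturated ring

The compounds below may be only part of what the source reports. "The series", "measured", "known", "first", "only" and "open" are said of these compounds alone.

Compound 1 `COc1ccc(C2OC(c3cc(OC)c(OC)c(OC)c3)=NN2C(C)=O)c(OC)c1`: 6.3%
Compound 2 `COc1cccc(/C=N/NC(=O)c2cc(OC)c(OC)c(OC)c2)c1OC`: -0.1%
Compound 3 `COc1ccc(OC)c(/C=N/NC(=O)c2cc(OC)c(OC)c(OC)c2)c1`: 0.1%

All three measured compounds were tested in a functional assay on BGC-823 cells (Homo sapiens) for antiproliferative activity, read by MTT assay, tested at 1 uM; a higher number here means a stronger effect of the compound at the concentration tested, a lower number a weaker effect. In this assay compound 1 gives 6.3%, compound 2 gives -0.1% and compound 3 gives 0.1%. Compound 1 holds the highest of the three numbers, but the gaps to compound 3 and to compound 2 both fall within the usual scatter, so the three cannot be told apart; all sit close to no effect.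

Compound 4 `COc1cc(C2=NN(C(C)=O)C(c3ccccc3F)O2)cc(OC)c1OC` shares the core of compound 1 and differs from it in one place: 2-fluorophenyl in place of 2,4-dimethoxyphenyl on a saturated ring carbon. Within the data shown here, no measured pair shows what this kind of exchange does, so the expectation rests on the near-zero reading of compound 1 alone. The step of a number 0.7 percentage points higher from compound 1 to compound 4 (within the scatter) is expected to stay within the scatter, with no clear direction. Compound 4 is therefore estimated to give 7%, in a range from -6% to 24%.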

Compound 4, a percentage reported as inhibition, at one concentration (the size of the read-out at that concentration, not a potency): 29.6%
Estimate against measurement, compound 4: 22.6 percentage points below; measured number outside the range, above it.
By their numbers in this assay, from the lowest: compounds 2, 3 and 1 (each within the scatter of the next); then compound 4.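

In this assay, 2-fluorophenyl in place of 2,4-dimethoxyphenyl on the saturated ring carbon gives a number 23.3 percentage points higher from compound 1 to compound 4 (beyond the scatter), the first gap among the compounds shown that lies beyond the scatter. The earlier readings all sat close to no effect, so this step shows that the group on this carbon can move the reading clear of that level while the rest of the core of compound 1 stays the same. Nothing available explains the step.

The compounds shown leave open whether the gain follows from the fluorine, from the loss of the two methoxy groups, or from both. An unsubstituted phenyl or a 2-chlorophenyl on this carbon would help separate these possibilities, and a pyridine ring or a carboxylic acid on the ring would test how much other change this position accepts.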